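Cytotoxicity of the shared core: a carbonyl in the linker

The source may hold more compounds than are shown below. What is called first, only, known or untested is meant among the compounds shown, and "the series" means these compounds.

Compound 3 `COc1ccc(-c2nc(CSc3cc(C)cc(C)c3)nc3ccsc23)cn1` stands at a limit in an ADME assay on cells (Homo sapiens) for cytotoxicity, read by resazurin assay, with a stated time of 5 days; a higher number here means that more compound is tolerated, a lower number that less compound is tolerated: compound 3 gives > 50000 nM, a limit of the assay and not a number. Compound 1 `COc1ccc(-c2nc(COc3cccc(Cl)c3)nc3ccsc23)cn1` also gives only a limit, > 50000 nM. Compound 2 `COc1ccc(-c2nc(C[S+]([O-])c3cccc(Cl)c3)nc3ccsc23)cn1` likewise gives only a limit, > 50000 nM. The steps a step that the two limits leave unreadable from compound 1 to compound 2, a step that the two limits leave unreadable from compound 1 to compound 3 and a step that the two limits leave unreadable from compound 2 to compound 3 cannot be sized, since all three values sit at the limit of > 50000 nM in this assay, at which 3 of the 3 values shown sit. Compound 4 `COc1ccc(-c2nc(CC(=O)c3cccc(Cl)c3)nc3ccsc23)cn1` differs from compound 3 by (3-chlorophenyl)carbonyl in place of (3,5-dimethylphenyl)sulfanyl on a saturated chain carbon bound to an aromatic carbon. Among the compounds with values here, no measured step bears readably on this change, and nothing points away from the limit. Compound 4 is therefore expected to sit at the same limit, an expected step that the limit leaves unreadable from compound 3 to compound 4 of no readable size, with an estimate of 60000 nM and a range of 30000 nM to 150000 nM.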

Compound 4, half-maximal cytotoxic concentration: 30000 nM
The estimate for compound 4 lay 2.0-fold (0.30 log units) above the measured number; the range from low to high includes it.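

Within the data shown here, compound 4 gives 30000 nM in this assay, a number and not a limit, so a linker carrying a carbonyl gives the first readable value at this position. The change gives an at least 1.6-fold lower number from compound 3 to compound 4 (0.22 log units; that floor lies within the scatter), an at least 1.6-fold lower number from compound 2 to compound 4 (0.22 log units; that floor lies within the scatter) and an at least 1.6-fold lower number from compound 1 to compound 4 (0.22 log units; that floor lies within the scatter), so only floors are known and none shows a real drop. The steps among compound 1, compound 2 and compound 3 remain unreadable: the limit of > 50000 nM in this assay, at which 3 of the 4 values shown sit.

On these data alone, how far the true steps reach past these floors stays open. Also open, as far as these compounds go, is whether an amine or a carboxylic acid in place of the carbonyl on this chain carbon would give a readable number in this assay.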